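A Methoxy Becomes Hydroxy on an Aromatic Ring

The compounds below may be only part of what the source reports. "The series", "measured", "known", "first", "only" and "open" are said of these compounds alone.

Values in a functional assay on HepG2 cells (Homo sapiens) for antiproliferative activity, read by MTT assay, with a stated time of 48 h (on this read-out higher numbers stand for weaker inhibition and lower numbers for stronger inhibition), for the measured compounds:
Compound 1 `COc1ccc(-c2c(Nc3ccc(F)cc3)c3ccc(OC)cc3oc2=O)cc1` gives > 100000 nM as a limit of the assay, not a number
Compound 2 `COc1ccc(-c2c(Nc3ccc(C)c(O)c3)c3ccc(OC)cc3oc2=O)cc1` gives 22500 nM
Compound 3 `COc1ccc(-c2c(Nc3cccc(C(F)(F)F)c3)c3ccc(OC)cc3oc2=O)cc1` gives 57300 nM

Compound 2 holds the lower of the two real numbers. For the measured compounds named here, the gap to the only other real number is a 2.5-fold higher number from compound 2 to compound 3 (0.41 log units; beyond the scatter) in this set.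

Compound 4 `COc1ccc(-c2c(Nc3ccc(C)c(O)c3)c3ccc(O)cc3oc2=O)cc1` is the next to be tested. The change is hydrogen in place of methyl on an oxygen on an aromatic ring, which turns methoxy into hydroxy.

The other measured steps are an at least 4.4-fold lower number from compound 1 to compound 2 (0.64 log units; beyond the scatter) and an at least 1.7-fold lower number from compound 1 to compound 3 (0.24 log units; that floor lies within the scatter) as shown. All three swap the group on nitrogen, so none of them tests this change. Going by the values given here, they show only that one swap elsewhere can shift the number modestly, and they give no direction here.

The expected result is therefore a 1.1-fold lower number from compound 2 to compound 4 (0.05 log units; within the scatter) with no step beyond the scatter as the best guess. Compound 4 is estimated at 20000 nM with an expected range from 7000 nM to 60000 nM in this assay.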

Compound 4, half-maximal inhibitory concentration: > 75300 nM
Compound 4: a limit, no number; the forecaster's own chance of this, stated with the estimate: 5%; at least 3.7-fold (0.57 log units) between middle value and limit.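

In this assay compound 4 gives > 75300 nM, which is a limit of the assay and not a number. Even so, the step can be read in one direction: replacing the methyl on this oxygen with hydrogen gives an at least 3.3-fold higher number from compound 2 to compound 4 (0.52 log units; beyond the scatter). The earlier compounds shown here differ only in the group on nitrogen, whereas this pair shows that the methoxy position also matters, since losing the methyl here weakens inhibition while the rest of compound 2 stays the same.

On these data alone, how much weaker compound 4 really is stays unknown, since the step gives only a floor, and a single change at this oxygen cannot show which feature of the methoxy counts. As far as these compounds go, whether a longer chain such as ethoxy or propoxy, or an amine in place of the methoxy, would keep or improve the number remains open.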